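Compound 1 to compound 4: an aryl exchange

A few compounds are considered here, and "the series" means these few. Any claim that something is new, unique, unknown or untested is made for them only; others in the source may bear on it.

In a functional assay on DU-145 cells (Homo sapiens) for antiproliferative activity, read by MTT assay, with a stated time of 48 h (a higher number here means a weaker inhibitor, a lower number a stronger inhibitor), compound 1 `C/C(=C\CC/C(C)=C/CC[C@@H]1[C@@]2(C)CCC(=O)C(C)(C)[C@H]2CC[C@@]1(C)O)CC/C=C(\C)C(=O)OCc1cn(-c2ccccc2C(F)(F)F)nn1` gives > 150000 nM, which is a limit and not a number. Compound 2 `C/C(=C\CC/C(C)=C/CC[C@@H]1[C@@]2(C)CCC(=O)C(C)(C)[C@H]2CC[C@@]1(C)O)CC/C=C(\C)C(=O)OCc1cn(-c2ccc(F)c(Cl)c2)nn1` gives > 150000 nM, also a limit. Compound 3 `C/C(=C\CC/C(C)=C/CC[C@@H]1[C@@]2(C)CCC(=O)C(C)(C)[C@H]2CC[C@@]1(C)O)CC/C=C(\C)C(=O)OCc1cn(-c2cccc([N+](=O)[O-])c2)nn1` gives > 150000 nM, again a limit. The series therefore offers no ranking so far, only (the limit of > 150000 nM in this assay, at which 3 of the 3 values shown sit).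

The next compound is compound 4 `COc1ccc(-n2cc(COC(=O)/C(C)=C/CC/C(C)=C/CC/C(C)=C/CC[C@@H]3[C@@]4(C)CCC(=O)C(C)(C)[C@H]4CC[C@@]3(C)O)nn2)cc1`, and the change is 4-methoxyphenyl in place of 2-(trifluoromethyl)phenyl on an aromatic nitrogen. It falls on an aromatic nitrogen of a five-membered aromatic ring with 3 nitrogen, the same place as the three measured aryl exchanges: a step that the two limits leave unreadable from compound 1 to compound 2, a step that the two limits leave unreadable from compound 1 to compound 3 and a step that the two limits leave unreadable from compound 2 to compound 3. None of these gives a size, so no direction can be assigned in this assay, and no step beyond the scatter is expected. The expected step is a step that the limit leaves unreadable from compound 1 to compound 4. Another report as a limit is the likeliest outcome. The estimate for compound 4 is 180000 nM, expected within 80000 nM to 400000 nM.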

Compound 4, half-maximal inhibitory concentration: 135000 nM
For compound 4 the middle estimate is 1.3-fold (0.12 log units) above the measured one, and the stated range covers the measured number.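

In this assay, going by these compounds alone, compound 4, with 4-methoxyphenyl on the aromatic nitrogen, gives the first value at this position that is a number and not a limit. Set against the three limits, the change gives an at least 1.1-fold lower number from compound 1 to compound 4 (0.04 log units; that floor lies within the scatter), an at least 1.1-fold lower number from compound 2 to compound 4 (0.04 log units; that floor lies within the scatter) and an at least 1.1-fold lower number from compound 3 to compound 4 (0.04 log units; that floor lies within the scatter); these are floors only, so they show no gain beyond the scatter and leave the true size of each step unknown. The other three aryl groups remain at the limit: the limit of > 150000 nM in this assay, at which 3 of the 4 values shown sit.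

The steps among compound 1, compound 2 and compound 3 cannot be read, so those aryl groups have no ranking. From the compounds shown here alone, it remains open whether an amine or a carboxylic acid on the phenyl ring would move the number in this assay clearly beyond the scatter.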